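Adding a bromine to a coumarin-linked lipoic acid amide

This account rests on a few compounds, and the source may have more. Where it says the series, first, only, none or still open, it means among the compounds named here.

Two compounds share a core that joins a cyclic disulfide acid, through an amide and a triazole, to a coumarin bearing a phenyl group. In a functional assay on PC-12 cells (Rattus norvegicus) for cytotoxicity, read by MTT assay, with stated times of 3 h and 2 h, tested at 20 uM (a higher number here means a stronger effect of the compound at the concentration tested, a lower number a weaker effect), compound 1 `O=C(CCCCC1CCSS1)NCc1cn(CCCOc2ccc3cc(-c4ccc(Br)cc4)c(=O)oc3c2)nn1` gives 69.1%, while compound 2 `O=C(CCCCC1CCSS1)NCc1cn(CCCCOc2ccc3cc(-c4ccccc4)c(=O)oc3c2)nn1` gives 26%, the lower of the two numbers, a gap that lies beyond the usual scatter. Compound 3 `O=C(CCCCC1CCSS1)NCc1cn(CCCCOc2ccc3cc(-c4ccc(Br)cc4)c(=O)oc3c2)nn1` has not yet been measured. It differs from compound 2 in one place: bromo in place of hydrogen on an aromatic carbon. Among the measured compounds shown here, no measured pair shows this exact change alone, so its effect is uncertain. Given that compound 1, which also carries the bromo group, reaches 69.1%, a moderate rise is expected, and the step of a number 19 percentage points higher from compound 2 to compound 3 (beyond the scatter) is estimated to go upward beyond the scatter. Compound 3 is therefore expected to give about 45%, within a range from 20% to 70%.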

Compound 3, a percentage reported as activity, at one concentration (the size of the read-out at that concentration, not a potency): 45%
Estimate against measurement, compound 3: no gap at the digits printed, and the stated range covers the measured number.
By their numbers in this assay, from the lowest: compound 2; then compound 3; then compound 1.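

In this assay, among the compounds shown here, the swap of phenyl for 4-bromophenyl, on an aromatic carbon para to a large group, comes out as a number 19 percentage points higher from compound 2 to compound 3 (beyond the scatter), the first view of this change with the rest of the molecule held fixed. The earlier gap between compound 1 and compound 2 mixed the bromo group with a difference in chain length, and this pair shows that the bromo group covers only part of that gap, since compound 3 at 45% still sits under compound 1 at 69.1%. No measurement here bears on why the number rises.

The compounds shown leave open whether the rise is specific to bromine or would also come with a chloro, methoxy or amine group at the same place. For the compounds shown here, they also leave open whether it would hold with a longer chain than the one in compound 3.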